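A few compounds are considered here, and "the series" means these few. Any claim that something is new, unique, unknown or untested is made for them only; others in the source may bear on it.

Of the compounds shown here, three have so far been tested in a functional assay on HT-1080 cells (Homo sapiens) for cytotoxicity, read by MTT assay, with a stated time of 72 h; a higher number here means a weaker inhibitor, a lower number a stronger inhibitor. Compound 2 `COc1cc(Nc2nc(C(=N)Nc3ccccc3)cc3c(-c4ccccc4)n[nH]c23)cc(OC)c1OC` gives 3900 nM there. Compound 1 `COc1cc(Nc2nc(C(=N)Nc3ccc(N4CCN(C)CC4)cc3)cc3c(-c4ccccc4)n[nH]c23)cc(OC)c1OC` carries a single change relative to compound 2, namely (4-methylpiperazin-1-yl in place of hydrogen on an aromatic carbon), and in this assay compound 1 gives 3400 nM. That step, a 1.1-fold lower number from compound 2 to compound 1 (0.06 log units; within the scatter), lies within the scatter, so the two numbers cannot be told apart. Compound 3 `COc1ccc(Cn2nc(-c3ccccc3)c3cc(C(=N)Nc4ccccc4)nc(NC4CCCCC4)c32)cc1` has a different core; how its core differs from that of compound 2 is not broken down here. In this assay compound 3 gives 3400 nM, level with compound 1 at the digits given and within the scatter of compound 2. Compound 4 `COc1ccc(Cn2nc(-c3ccccc3)c3cc(C(=N)Nc4ccc(N5CCN(C)CC5)cc4)nc(NC4CCCCC4)c32)cc1` has not yet been measured. It differs from compound 3 by 4-methylpiperazin-1-yl in place of hydrogen on an aromatic carbon, the same change that separates compound 2 from compound 1, made at the same place in the ring. Because the earlier step of a 1.1-fold lower number from compound 2 to compound 1 (0.06 log units; within the scatter) stayed within the scatter, a similarly small step is expected here, a 1.1-fold lower number from compound 3 to compound 4 (0.03 log units; within the scatter). Compound 4 is therefore estimated to give 3200 nM in this assay, with a likely range from 1600 nM to 6400 nM.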

Compound 4, half-maximal inhibitory concentration: 640 nM
For compound 4 the middle estimate is 5.0-fold (0.70 log units) above the measured one; measured number below the stated range.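

In this assay, the new step is a 5.3-fold lower number from compound 3 to compound 4 (0.73 log units; beyond the scatter), so adding 4-methylpiperazin-1-yl does not have the same effect on both cores, and the gap between the two results is larger than repeat measurements would explain: the same change on two cores in this assay, a 1.1-fold lower number (0.06 log units; within the scatter) from compound 2 to compound 1 and a 5.3-fold lower number (0.73 log units; beyond the scatter) from compound 3 to compound 4, 4.6-fold (0.67 log units) apart, beyond the scatter of two such steps The size of a step seen on one core therefore cannot simply be carried over to another in this series, and the small step first seen on the core of compound 2 gave no reliable guide to the larger one on the core of compound 3. Among these compounds, these results do not show why the cores respond differently, since the two cores are not compared one difference at a time, and with only two cores they set no general rule for the series.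

From the compounds shown here alone, it remains open whether a morpholine ring or a piperazine without the methyl group would give a similar step on the core of compound 3. Going by these compounds, it also remains open which part of that core matters for the larger step.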